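Piperidin-1-yl to cyclohexyl on the sulfonyl sulfur, second core

The source may hold more compounds than are shown below. What is called first, only, known or untested is meant among the compounds shown, and "the series" means these compounds.

Measured so far in an assay on isolated protein for displacement of a labelled ligand from 5-hydroxytryptamine receptor 6 (Homo sapiens), read by scintillation counting, with a stated time of 1 h; on this read-out higher numbers stand for weaker inhibition and lower numbers for stronger inhibition:

compound 1, `CN(C)c1cccc2c1ccn2S(=O)(=O)N1CCCCC1`, gives 39100 nM
compound 2, `CN(C)c1cccc2c1ccn2S(=O)(=O)C1CCCCC1`, gives 4890 nM
compound 3, `O=S(=O)(N1CCCCC1)n1ccc2ccc(-c3ccncc3)cc21`, gives 1660 nM

Within the core shared by compound 1 and compound 2, the single change cyclohexyl in place of piperidin-1-yl on a sulfonyl sulfur produced an 8.0-fold lower number from compound 1 to compound 2 (0.90 log units; beyond the scatter). Among the compounds with values here, that is the only step so far in which this change has been measured.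

Compound 3 carries a different core; how it differs from compound 1 is not broken down here. Among the three measured compounds compound 3 gives the lowest number in this assay, with the nearest being compound 2 and the furthest compound 1, both separated by steps beyond the scatter.

Compound 4, `O=S(=O)(C1CCCCC1)n1ccc2ccc(-c3ccncc3)cc21`, is not yet measured. It is related to compound 3 by cyclohexyl in place of piperidin-1-yl on a sulfonyl sulfur. Within the data shown here, this is the same change, at the same kind of place, as the one from compound 1 to compound 2, so the step on the first core is the only guide for the step on the second.

For compound 4 the step expected in this assay is a 4.7-fold lower number from compound 3 to compound 4 (0.68 log units; beyond the scatter), set beside the measured 8.0-fold lower number from compound 1 to compound 2 (0.90 log units; beyond the scatter). Among the measured compounds shown here, the expectation is kept somewhat smaller than that earlier step because an 8.0-fold lower number from compound 1 to compound 2 (0.90 log units; beyond the scatter) is the only example of this change and it stands on a different core. Compound 4 is therefore estimated at 350 nM, with the range 100 nM to 1200 nM.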

Compound 4, inhibition constant: 2180 nM
Compound 4: the middle estimate sits 6.2-fold (0.79 log units) below what was measured; measured number above the stated range.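

In this assay, the replacement of piperidin-1-yl by cyclohexyl on a sulfonyl sulfur does not carry over from one core to the other: the same change on two cores in this assay, an 8.0-fold lower number (0.90 log units; beyond the scatter) from compound 1 to compound 2 and a 1.3-fold higher number (0.12 log units; within the scatter) from compound 3 to compound 4, 11-fold (1.02 log units) apart, beyond the scatter of two such steps. On the core of compound 3 the change gives a 1.3-fold higher number from compound 3 to compound 4 (0.12 log units; within the scatter), so at this position on that core the assay does not separate the two groups, and the clear step seen on the core of compound 1 cannot be treated as a property of the change alone. Within the data shown here, this shows that the size of the step depends on the core in these two pairs, but it does not show which part of the core is responsible, since the two cores differ in more than one place and only one pair stands on each.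

Still open, as far as these compounds go, is whether a third core would follow the pair compound 1 and compound 2, the pair compound 3 and compound 4, or neither, and which feature of the core decides this. Also open, from the compounds shown here alone, is how other groups on the sulfonyl sulfur, such as phenyl, morpholin-4-yl or an open-chain amine, would behave on each of the two cores.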